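Two Configurations Behind One Undefined Stereocentre

The source may hold more compounds than are shown below. What is called first, only, known or untested is meant among the compounds shown, and "the series" means these compounds.

Compound 1, `CC(C)(C)OC(=O)CN1C(=O)C(NC(=O)c2cc3ccccc3[nH]2)CCc2ccccc21`, in an assay for binding affinity to Cholecystokinin receptor (Rattus norvegicus), read by CCK-8 assay (a lower number here means a stronger inhibitor, a higher number a weaker inhibitor), gives 7 nM.
Compound 2, `CC(C)(C)OC(=O)CN1C(=O)[C@@H](NC(=O)c2cc3ccccc3[nH]2)CCc2ccccc21`, in this assay gives 200 nM.

Compound 2 stands with the higher of the two numbers, and the step of a 29-fold higher number from compound 1 to compound 2 (1.46 log units; beyond the scatter) sets it apart from compound 1. The two differ only in that (the fact that one of compounds 1 and 2 is drawn with a defined configuration and the other without, at the place where they differ), so compound 1 represents both configurations together while compound 2 holds just one of them. Compound 3, `CC(C)(C)OC(=O)CN1C(=O)[C@H](NC(=O)c2cc3ccccc3[nH]2)CCc2ccccc21`, completes the pair: the two compounds have the same atoms and bonds and differ only in configuration as drawn: 1 of 1 stereo elements differ; a stereocentre at a saturated ring carbon is drawn S in compound 2 and R in compound 3. Within the data shown here, the single measured step bears on this change: compound 1, drawn without a configuration, reached a much lower number than compound 2, and since compound 1 contains both configurations, the weaker one cannot account for that number on its own. The other configuration must therefore carry most of the binding, and a large step downward, beyond the scatter, is expected in this assay from compound 2 to compound 3, plausibly as large as the step that separated compound 1 from compound 2. Compound 3 is estimated at 4 nM, within a range from 1.5 nM to 12 nM, corresponding to an expected step of a 50-fold lower number from compound 2 to compound 3 (1.70 log units; beyond the scatter).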

Compound 3, half-maximal inhibitory concentration: 3 nM
The estimate for compound 3 lay 1.3-fold (0.12 log units) above the measured number; low and high end bracket the measured number.
By their numbers in this assay, from the lowest: compound 3; then compound 1; then compound 2.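

In this assay, the configuration at this saturated ring carbon alone decides the outcome, with a 67-fold lower number from compound 2 to compound 3 (1.82 log units; beyond the scatter), and this comparison involves no other structural change: the fact that compounds 2 and 3 differ only in the configuration as drawn. The R configuration also improves on the drawing without a configuration, with a 2.3-fold lower number from compound 1 to compound 3 (0.37 log units; beyond the scatter), a modest step but one beyond the scatter, which fits compound 1 containing some of the weaker form alongside the stronger one: the fact that one of compounds 1 and 3 is drawn with a defined configuration and the other without, at the place where they differ. Where the earlier compounds allowed the R form's contribution only to be inferred, compound 3 now shows directly that R is the favoured configuration at this position, while compound 2, the S form, still gives 200 nM.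

The proportion of the two configurations in compound 1 is not given, so the size of the step to compound 3 cannot be converted into a composition for that sample. As far as these compounds go, whether R remains favoured, and by a similar margin, when the ester on the shared core is replaced by a carboxylic acid or an amide, or when a longer chain connects that group to the core, remains open.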